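Swapping isopropyl for bromo on the para-substituted phenyl

The compounds below may be only part of what the source reports. "The series", "measured", "known", "first", "only" and "open" are said of these compounds alone.

Compound 3, `COc1cccc(OC)c1C(=O)Nc1nnc(-c2ccc(C(C)C)cc2)s1`, gives 398 nM in a functional assay on the whole organism (integument) for inhibition, with Chilo suppressalis as the target, read by scintillation counting, with a stated time of 72 h; on this read-out higher numbers stand for weaker inhibition and lower numbers for stronger inhibition. Among the two numbers available, compound 3 stands highest, and the only compound in its neighbourhood is compound 1, `COc1cccc(OC)c1C(=O)Nc1nnc(-c2ccc(Cl)cc2)s1`, which in this assay gives 58.9 nM. Compound 2, `O=C(Nc1nnc(-c2ccc(Cl)cc2)s1)c1ccccc1Br`, in this assay reaches only a limit of the assay, > 5010 nM; this is one of the values sitting at the limit of > 5010 nM in this assay, at which 1 of the 3 values shown sits, rather than a number.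

The step now under consideration leads from compound 3 to compound 4, `COc1cccc(OC)c1C(=O)Nc1nnc(-c2ccc(Br)cc2)s1`, and reads (bromo in place of isopropyl on an aromatic carbon). For the measured compounds named here, one measured step bears directly on it: the one from compound 1 to compound 3, where isopropyl replaced chloro on the same aromatic carbon and which gave a 6.8-fold higher number from compound 1 to compound 3 (0.83 log units; beyond the scatter). The present change removes that isopropyl again and puts bromo, a single halogen atom, in the place where compound 1 carries chloro. The expectation is therefore a step in the opposite direction, that is a lower number in this assay, of roughly the size seen between compound 1 and compound 3, bringing compound 4 back near compound 1.

On this basis compound 4 is expected to give about 80 nM in this assay, most likely between 30 nM and 250 nM, which would mean an expected step of a 5.0-fold lower number from compound 3 to compound 4 (0.70 log units; beyond the scatter).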

Compound 4, half-maximal inhibitory concentration: 66.1 nM
Compound 4: the middle estimate sits 1.2-fold (0.08 log units) above what was measured; low and high end bracket the measured number.
By their numbers in this assay, from the lowest: compounds 1 and 4 (each within the scatter of the next); then compound 3. At a limit, above all of these: compound 2.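

In this assay, for the compounds shown here, the earlier compounds showed only that isopropyl gave a higher number than chloro on this aromatic carbon, so that step could have reflected something particular to the chloro compound; the new result, a 6.0-fold lower number from compound 3 to compound 4 (0.78 log units; beyond the scatter), shows that a second halogen also stands clearly apart from isopropyl. The other new step, a 1.1-fold higher number from compound 1 to compound 4 (0.05 log units; within the scatter), shows that chloro and bromo cannot be told apart at this position, so within these compounds the exchange of one halogen for the other leaves the read-out unchanged, whereas replacing either with isopropyl does not. Nothing shown here explains the difference between the two halogens and isopropyl.

As far as these compounds go, it remains open whether fluoro, methyl, methoxy or tert-butyl on this carbon would group with the two halogens or with isopropyl, and therefore whether isopropyl is a special case. From the compounds shown here alone, it is equally open whether the match between chloro and bromo would persist if the two methoxy groups of the shared core were replaced by ethoxy groups or by fluoro.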